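Swapping trifluoromethyl for fluoro on a long-lived core

The source may hold more compounds than are shown below. What is called first, only, known or untested is meant among the compounds shown, and "the series" means these compounds.

Compound 1 `O=C(NCc1ccccc1C(F)(F)F)N1C(=O)c2ccccc2S1(=O)=O` was tested in a physicochemical assay for pharmacokinetics (a lower number here means that the compound disappears faster, a higher number that the compound lasts longer), where compound 1 gives > 166 h, which is a limit of the assay rather than a number. Compound 1 therefore sits at the limit of > 166 h in this assay, at which 3 of the 3 values shown sit. Compound 2 `O=C(OCc1ccccc1)N1C(=O)c2ccccc2S1(=O)=O` shares the same core, and in this assay compound 2 gives > 166 h, again a limit. Compound 3 `CC(NC(=O)N1C(=O)c2ccccc2S1(=O)=O)c1ccccc1` likewise reaches a limit, as in this assay compound 3 gives > 166 h. Compound 4 `O=C(NCc1ccccc1F)N1C(=O)c2ccccc2S1(=O)=O` differs from compound 1 in one place: fluoro in place of trifluoromethyl on an aromatic carbon. Within the data shown here, no step between measured compounds is known here. The step expected for compound 4 in this assay is a number no higher from compound 1 to compound 4 (the limit leaves the size open), nothing beyond the usual scatter. Compound 4 is thus expected to give 166 h in this assay, within 100 h to 300 h, most likely again as a limit.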

Compound 4, half-life: > 166 h
Compound 4 gave a limit, no number; the forecaster's own chance of this, stated with the estimate: 85%; the middle value lies on the limit itself.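

No step from compound 1 to compound 4 can be read in this assay, because both results are limits rather than numbers: the limit of > 166 h in this assay, at which 4 of the 4 values shown sit.

The compounds shown leave open how long each one actually lasts, and whether fluoro in place of trifluoromethyl changes that at all.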